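Methoxy-to-hydroxy step on the pyrazole series

This account rests on a few compounds, and the source may have more. Where it says the series, first, only, none or still open, it means among the compounds named here.

Measured compounds:
compound 1 `Cc1cc(O)cc(-c2nn(CC#N)cc2-c2ccnc(-c3ccc(Oc4ccccc4)cc3)c2)c1`: 24400 nM
compound 2 `COc1cc(C)cc(-c2nn(CC#N)cc2-c2ccnc(-c3ccc(N(C)C)cc3)c2)c1`: 882 nM

Among the measured compounds shown here, in a functional assay on SK-OV-3 cells (Homo sapiens) for inhibition, read by sulforhodamine B assay, with a stated time of 48 h (a lower number here means a stronger inhibitor of growth, a higher number a weaker inhibitor of growth), compound 2 gives 882 nM, the lower of the two numbers so far. Compound 1 gives 24400 nM in this assay, a higher number that lies beyond the scatter. For the measured compounds named here, compound 1 and compound 2 differ in two places, so the two values show only that compound 2 is the stronger of the pair; nothing can be attributed to either difference alone.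

Compound 3 `Cc1cc(O)cc(-c2nn(CC#N)cc2-c2ccnc(-c3ccc(N(C)C)cc3)c2)c1` is not yet measured in this assay. Relative to compound 2 the change is hydrogen in place of methyl on an oxygen on an aromatic ring, that is methoxy to hydroxy, 3-methoxy-5-methylphenyl to 3-hydroxy-5-methylphenyl. Going by the values given here, no single-change step of this kind is available. Compound 1 carries the same hydroxy group but also a different aryl on the far side, so its value cannot be read as a guide to this step.

The expectation for compound 3 is a small step, a 1.7-fold higher number from compound 2 to compound 3 (0.23 log units; within the scatter), possibly none beyond the scatter. Compound 3 is estimated at 1500 nM, with a range from 500 nM to 5000 nM.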

Compound 3, concentration for total growth inhibition: 8030 nM
For compound 3 the middle estimate is 5.4-fold (0.73 log units) below the measured one; the whole stated range lies below it.
By their numbers in this assay, from the lowest: compound 2; then compound 3; then compound 1.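

In this assay the methyl on the oxygen proves to matter: methoxy to hydroxy gives a 9.1-fold higher number from compound 2 to compound 3 (0.96 log units; beyond the scatter) in the dimethylamino series, a change of one heavy atom that reaches beyond the scatter. With the hydroxy group held constant, dimethylamino in place of phenoxy gives a 3.0-fold lower number from compound 1 to compound 3 (0.48 log units; beyond the scatter), so the aryl substituent also moves the number on its own, and of the two single changes the methoxy-to-hydroxy step is the larger here. No measurement shown gives a reason for either step.

As far as these compounds go, the size of the methoxy-to-hydroxy step is known only with dimethylamino on the other aryl, so whether it holds with phenoxy there remains open, as does whether the two changes simply add. From the compounds shown here alone, it also remains open how an ethoxy group or a longer alkoxy chain on that oxygen, or an amine in place of the hydroxy group on the 3-hydroxy-5-methylphenyl ring, would compare with compound 2 in this assay.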